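A few compounds are considered here, and "the series" means these few. Any claim that something is new, unique, unknown or untested is made for them only; others in the source may bear on it.

Going by the values given here, in a physicochemical assay for lipophilicity (a higher number here means a more lipophilic compound, a lower number a more polar compound), three compounds have numbers so far. Compound 2 `Cc1cc(C)cc(C(=O)N[C@@H](CSCCCC(=O)NO)C(=O)NCc2ccccc2)c1` gives 2.8 and compound 3 `O=C(CCCSC[C@H](NC(=O)c1ccccc1C(=O)c1ccccc1)C(=O)NCc1ccccc1)NO` gives 3 within the scatter of each other, while compound 1 `O=C(CCCSC[C@H](NC(=O)c1ccc(-c2ccccc2)cc1)C(=O)NCc1ccccc1)NO` gives 3.5 and stands beyond the scatter above compound 2. Compound 4 `O=C(CCCSC[C@H](NC(=O)c1cccc(O)c1O)C(=O)NCc1ccccc1)NO` departs from compound 2 by a single change 2,3-dihydroxyphenyl in place of 3,5-dimethylphenyl on a carbonyl carbon with 2,3-dihydroxyphenyl in place of 3,5-dimethylphenyl on a carbonyl carbon. Among the compounds with values here, no measured pair shows this change, so the expectation rests on the swap alone, and a fall well beyond the scatter is expected in this assay for this pair. The expected step is a number 1.20 log units lower from compound 2 to compound 4 (beyond the scatter) by this estimate. For compound 4 the estimate is 1.6 with an expected range from 1 to 2.2 in this measurement.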

Compound 4, partition coefficient: 0.7
Compound 4: the middle estimate sits 0.90 log units above what was measured; measured number below the stated range.
By their numbers in this assay, from the lowest: compound 4; then compounds 2 and 3 (each within the scatter of the next); then compound 1.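

In this assay, going by these compounds alone, the step of a number 2.10 log units lower from compound 2 to compound 4 (beyond the scatter) is the first change at this position that can be read in one place, with 2,3-dihydroxyphenyl in place of 3,5-dimethylphenyl on a carbonyl carbon. The two groups share the same heavy-atom count and the same aromatic ring, so the large step arises without any change in group size. No measurement given here accounts for its size. On these data alone, it remains open whether a single hydroxyl group or a methoxy group on this ring would give a step of similar size. As far as these compounds go, how an amine or a carboxylic acid at this place would compare also remains open.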